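Replacing the Oxadiazolyl Group: an Estimate for Compound 3

The source may hold more compounds than are shown below. What is called first, only, known or untested is meant among the compounds shown, and "the series" means these compounds.

Compound 1 `Cc1nnc(SCc2coc3ccc(Cl)cc3c2=O)o1` and compound 2 `Cc1nnc(SCc2coc3ccccc3c2=O)o1` share a core and differ in one place, hydrogen in place of chloro on an aromatic carbon. In a functional assay on MCF7 cells (Homo sapiens) for cytotoxicity, read by MTT assay, with a stated time of 72 h (a higher number here means a weaker inhibitor, a lower number a stronger inhibitor), compound 1 gives 5000 nM, and compound 2 gives 4600 nM. The step of a 1.1-fold lower number from compound 1 to compound 2 (0.04 log units; within the scatter) lies within the scatter, so on the numbers shown compound 2 stands alongside compound 1 rather than apart from it.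

Compound 3 `Cc1nnc(SCc2coc3ccccc3c2=O)s1` has not been measured. It differs from compound 2 by 5-methyl-1,3,4-thiadiazol-2-yl in place of 5-methyl-1,3,4-oxadiazol-2-yl on a sulfur. Among the compounds with values here, no measured step concerns this kind of change; the only step available, a 1.1-fold lower number from compound 1 to compound 2 (0.04 log units; within the scatter), touches a different place and was itself within the scatter. The expectation is therefore a step of no change at the digits printed from compound 2 to compound 3 (within the scatter) that stays within the scatter. Compound 3 is estimated at 4600 nM in this assay, with an expected range from 2300 nM to 9200 nM.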

Compound 3, half-maximal inhibitory concentration: 6700 nM
Compound 3: the middle estimate sits 1.5-fold (0.16 log units) below what was measured, and the stated range covers the measured number.
By their numbers in this assay, from the lowest: compounds 2, 1 and 3 (each within the scatter of the next).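

In this assay, exchanging 5-methyl-1,3,4-oxadiazol-2-yl for 5-methyl-1,3,4-thiadiazol-2-yl on a sulfur gives a 1.5-fold higher number from compound 2 to compound 3 (0.16 log units; within the scatter). Unlike the earlier chloro step, this one touches the group on the sulfur itself, and it shows that replacing the oxygen of that ring with sulfur does not separate the two compounds in this assay. No supporting measurement is available to explain how the two groups compare here.

On these data alone, it remains open whether a more distant replacement on the sulfur, such as a phenyl ring, or an amine or a carboxylic acid in place of the methyl, would move the number beyond the scatter. As far as these compounds go, it is also open whether the chloro group would read the same with the 5-methyl-1,3,4-thiadiazol-2-yl group in place.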